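Cytotoxicity on Prostate Cancer Cells Across Three Piperidine Amides

This account rests on a few compounds, and the source may have more. Where it says the series, first, only, none or still open, it means among the compounds named here.

This account covers two measured compounds and one that awaits measurement in an ADME assay on PC-3 cells (Homo sapiens) for cytotoxicity, read by WST assay, tested at 100 uM; a lower number here means less inhibition, a higher number more inhibition at the concentration tested (going by the name of the read-out). Compound 1 `O=C(Nc1ccc(Cl)cc1)C1CCCN(C(=O)c2cccc(-c3ccco3)c2)C1` carries a furan-2-yl group on one of its benzoyl rings, and in this assay compound 1 gives 0%. Compound 2 `O=C(Nc1cccc(Cc2ccccc2)c1)C1CCCN(C(=O)c2cc(C(F)(F)F)cc(C(F)(F)F)c2)C1`, with two trifluoromethyl groups on the corresponding ring and a benzyl group on the anilide, gives 0% in this assay. Compound 1 therefore stands level with compound 2 within the scatter of the measurement, and neither shows any inhibition at the tested concentration.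

Compound 3 `COC(=O)c1cccc(C(=O)N2CCCC(C(=O)Nc3ccc(Cl)cc3)C2)c1` differs from compound 1 in one place: methoxycarbonyl in place of furan-2-yl on an aromatic carbon. The methoxycarbonyl group replaces the furan-2-yl group on the shared core.

Since both measured compounds show no inhibition, the step of no change at the digits printed from compound 1 to compound 3 (within the scatter) is expected to stay within the scatter. Compound 3 is expected to give 0% in this assay, with a range from -5% to 10%.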

Compound 3, a percentage reported as inhibition, at one concentration (the size of the read-out at that concentration, not a potency): 0%
The estimate for compound 3 equals the measured number at the digits printed, within the range that was stated.
By their numbers in this assay, from the lowest: compounds 1, 2 and 3 (each within the scatter of the next).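

In this assay, putting methoxycarbonyl in place of furan-2-yl on an aromatic carbon, meta to a large group, gives no change at the digits printed from compound 1 to compound 3 (within the scatter). Compound 1 and compound 2 differ in more than one place, so this step is the only one here that isolates a single position, and it shows that a group with no ring can replace a five-membered aromatic ring without moving the read-out beyond the scatter. No evidence is available that bears on this result.

Since compound 3 gives 0%, like compound 1 and compound 2, the compounds shown do not reveal whether any group at this position can produce inhibition at the tested concentration. An amine, a carboxylic acid or a longer chain at this place remains an open case.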